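Swapping the piperazine tail for a plain methyl

This account rests on a few compounds, and the source may have more. Where it says the series, first, only, none or still open, it means among the compounds named here.

Measured so far in an ADME assay on MT4 cells (Homo sapiens) for cytotoxicity, read by MTT assay, with a stated time of 96 h; on this read-out higher numbers stand for lower toxicity in this test and lower numbers for higher toxicity in this test:
- compound 1 `CN1CCN(CC(=O)Nc2ccc(-c3nc4cc(Cl)c(Cl)cc4[nH]3)cc2)CC1`: 11000 nM
- compound 2 `CN1CCN(CC(=O)Nc2ccc(-c3nc4cc(C(F)(F)F)ccc4n3C)cc2)CC1`: 22000 nM

Compound 2 sits at one end of these two numbers, yet its gap to compound 1 lies within the usual scatter, so the pair reads as alike. Compound 3 `CCC(=O)Nc1ccc(-c2nc3cc(C(F)(F)F)ccc3n2C)cc1` differs from compound 2 by methyl in place of 4-methylpiperazin-1-yl on a saturated chain carbon bound to a carbonyl carbon. Among the measured compounds shown here, no measured pair shows this change, so no direction is given by the data. The step from compound 2 to compound 3 is expected to be small, a 1.1-fold lower number from compound 2 to compound 3 (0.04 log units; within the scatter), not beyond the scatter. Compound 3 is therefore estimated at 20000 nM, between 6000 nM and 60000 nM.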

Compound 3, half-maximal cytotoxic concentration: 8000 nM
Compound 3: middle estimate off by 2.5-fold (0.40 log units), on the high side; the range from low to high includes it.
By their numbers in this assay, from the lowest: compounds 3, 1 and 2 (each within the scatter of the next, the first and the last beyond it).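

In this assay, methyl in place of 4-methylpiperazin-1-yl on a saturated chain carbon bound to a carbonyl carbon gives a 2.8-fold lower number from compound 2 to compound 3 (0.44 log units; beyond the scatter), a modest step beyond the scatter. Among the compounds shown here, this is the first sign that this position matters to the read-out: without the piperazine ring, toxicity in this test is higher. Nothing measured here accounts for the shift.

Going by these compounds, whether a dimethylamino group or a morpholine ring here would read closer to compound 2 or to compound 3 stays open. So does whether the same swap on the core of compound 1 moves its number the same way.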